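Bromo to Nitro on the Side-Chain Phenyl: An Expected Value

A few compounds are considered here, and "the series" means these few. Any claim that something is new, unique, unknown or untested is made for them only; others in the source may bear on it.

Compound 1 `O=C(/C=C/c1ccccc1Br)NNC(=O)c1ccc2c(c1)OCCO2`: 2110 nM
Compound 2 `O=C(/C=C/c1cccc(Br)c1)NNC(=O)c1ccc2c(c1)OCCO2`: 3330 nM

Both compounds were tested in a functional assay on cells (Cancer cell lines, Homo sapiens) for inhibition, read by MTT assay, with a stated time of 48 h; a higher number here means a weaker inhibitor, a lower number a stronger inhibitor. Among the measured compounds shown here, the only measured step, a 1.6-fold higher number from compound 1 to compound 2 (0.20 log units; within the scatter), lies within the scatter, so compound 2 and compound 1 cannot be told apart on these numbers. Compound 3 `O=C(/C=C/c1cccc([N+](=O)[O-])c1)NNC(=O)c1ccc2c(c1)OCCO2` differs from compound 2 by nitro in place of bromo on an aromatic carbon. For the measured compounds named here, no measured step exchanges one kind of substituent for another, so nothing here tells how this change will read. Compound 3 is therefore expected to give 3000 nM, within 900 nM to 10000 nM, an expected step of a 1.1-fold lower number from compound 2 to compound 3 (0.05 log units; within the scatter).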

Compound 3, half-maximal inhibitory concentration: 1560 nM
The estimate for compound 3 lay 1.9-fold (0.28 log units) above the measured number; the range from low to high includes it.
By their numbers in this assay, from the lowest: compounds 3, 1 and 2 (each within the scatter of the next, the first and the last beyond it).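

Nitro in place of bromo on this aromatic carbon gives the first step beyond the scatter in this series (a 2.1-fold lower number from compound 2 to compound 3 (0.33 log units; beyond the scatter)) in this assay, though the step is modest. The 3-nitrophenyl and 2-bromophenyl compounds still cannot be told apart (a 1.4-fold lower number from compound 1 to compound 3 (0.13 log units; within the scatter)), so the change separates compound 3 from only one of the two bromo compounds. No measurement shown explains either step. As far as these compounds go, whether an amine or a carboxylic acid on this same carbon would read differently from nitro and bromo remains open.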